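Adding a second chloro to the sulfonyl aryl group

The source may hold more compounds than are shown below. What is called first, only, known or untested is meant among the compounds shown, and "the series" means these compounds.

Compound 1 `CC1=NN(S(=O)(=O)c2ccccc2C)C(c2cc(Br)ccc2O)C1`: 39300 nM
Compound 2 `CC1=NN(S(=O)(=O)c2ccc(F)cc2)C(c2cc(Br)ccc2O)C1`: 50100 nM
Compound 3 `CC1=NN(S(=O)(=O)c2ccc(Cl)cc2)C(c2cc(Br)ccc2O)C1`: > 60000 nM (a limit)

In a functional assay on HepG2 cells (Homo sapiens) for antiproliferative activity, read by MTT assay, with a stated time of 48 h (on this read-out lower numbers stand for an effect already at smaller amounts and higher numbers for an effect only at larger amounts of compound), compound 3 gives only a limit, > 60000 nM, and no number. Compound 4 `CC1=NN(S(=O)(=O)c2ccc(Cl)cc2Cl)C(c2cc(Br)ccc2O)C1` carries 2,4-dichlorophenyl where compound 3 has 4-chlorophenyl: chloro in place of hydrogen on an aromatic carbon. Resting on an at least 1.1-fold higher number from compound 2 to compound 3 (0.07 log units; that floor lies within the scatter) and an at least 1.5-fold higher number from compound 1 to compound 3 (0.18 log units; that floor lies within the scatter), whose floors lie within the scatter, no shift beyond the scatter is expected in this assay, though neither step adds a chloro in place of hydrogen. The expected change is a number no higher from compound 3 to compound 4 (the limit leaves the size open). For compound 4 the estimated value is 60000 nM, with an expected range from 30000 nM to 100000 nM.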

Compound 4, half-maximal effective concentration: 45200 nM
Compound 4: middle estimate off by 1.3-fold (0.12 log units), on the high side; the measured number falls inside the stated range.
By their numbers in this assay, from the lowest: compounds 1, 4 and 2 (each within the scatter of the next). At a limit, above all of these: compound 3.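

In this assay chloro in place of hydrogen, ortho to a large group, brings an at least 1.3-fold lower number from compound 3 to compound 4 (0.12 log units; that floor lies within the scatter). The starting point of that step is a limit and not a number: the limit of > 60000 nM in this assay, at which 1 of the 4 values shown sits. The 2,4-dichlorophenyl group also stays level with the other two sulfonyl aryl groups, with a 1.1-fold lower number from compound 2 to compound 4 (0.04 log units; within the scatter) and a 1.2-fold higher number from compound 1 to compound 4 (0.06 log units; within the scatter).

The compounds shown leave open whether an amine or a carboxylic acid, ortho to a large group in place of the chloro, would shift the number beyond the scatter.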